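Bromo Substitution on a Pyridyl Triazole Anticonvulsant Scaffold

This account rests on a few compounds, and the source may have more. Where it says the series, first, only, none or still open, it means among the compounds named here.

Compound 2: `c1ccc(-n2nncc2-c2cccnc2)cc1` — 76.4 mg/kg
Compound 1: `Clc1ccc(N2N=NCC2c2ccncc2)cc1` — 257 mg/kg

Going by the values given here, in a functional assay on the whole organism with Mus musculus as the target, in the maximal electroshock model (a higher number here means that more compound is needed for the effect, a lower number that less compound is needed), compound 2 gives 76.4 mg/kg, the lowest of the two numbers measured so far. Compound 1, `Clc1ccc(N2N=NCC2c2ccncc2)cc1`, differs from it in several places at once, and in this assay compound 1 gives 257 mg/kg, a number beyond the scatter of that for compound 2. The two compounds differ in more than one place. The comparison therefore teaches little about any single change.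

Compound 3, `Brc1ccc(-n2nncc2-c2cccnc2)cc1`, keeps the whole core of compound 2 and changes it in one place: bromo in place of hydrogen on an aromatic carbon. Among the compounds with values here, no measured pair in this set shows such a change on its own, so the direction of the step is open. Compound 3 is expected to give a number close to that of compound 2, with the step of a 1.2-fold lower number from compound 2 to compound 3 (0.07 log units; within the scatter) not clearly beyond the scatter. Compound 3 is estimated at 65 mg/kg, in the range 25 mg/kg to 170 mg/kg.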

Compound 3, dose for half-maximal effect: 87.2 mg/kg
Estimate against measurement, compound 3: 1.3-fold (0.13 log units) below; the range from low to high includes it.
By their numbers in this assay, from the lowest: compounds 2 and 3 (each within the scatter of the next); then compound 1.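

Going by these compounds alone, this is the first change in the set made in one place only, so it gives a direct reading of this position, on the six-membered aromatic ring of carbon only and para to a large group. In this assay, bromo in place of hydrogen gives a 1.1-fold higher number from compound 2 to compound 3 (0.06 log units; within the scatter), so compound 2 and compound 3 cannot be told apart, and the position takes this single bromine atom with no clear effect on the dose needed. No measurement on hand offers an explanation for this result.

From the compounds shown here alone, whether fluorine, an amine or a carboxylic acid would be tolerated at this position remains open. Going by these compounds, it is also open whether bromo would behave the same way elsewhere on this ring or on the core of compound 1.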